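The compounds below may be only part of what the source reports. "The series", "measured", "known", "first", "only" and "open" are said of these compounds alone.

In a functional assay on HCT-116 cells (Homo sapiens) for inhibition, read by fluorescence, with a stated time of 48 h (on this read-out higher numbers stand for weaker inhibition of growth and lower numbers for stronger inhibition of growth), compound 2 `N[C@H](C(=O)OCCCOC1(c2ccc(Cl)cc2)c2ccccc2C(=O)N1Cc1ccccc1)c1ccccc1` gives 14000 nM. This lies within the scatter of compound 1 `CC(C)[C@H](N)C(=O)OCCCOC1(c2ccc(Cl)cc2)c2ccccc2C(=O)N1Cc1ccc(Cl)cc1` at 16000 nM and of compound 3 `CC(C)[C@H](N)C(=O)OCC(C)(C)COC1(c2ccc(Cl)cc2)c2ccccc2C(=O)N1Cc1ccc(Cl)cc1` at 11000 nM, so the three measured compounds form one flat group with no clear order.

Compound 4 `CC(=O)OCCCOC1(c2ccc(Cl)cc2)c2ccccc2C(=O)N1Cc1ccccc1` is the next case. Relative to compound 2 the difference is methyl in place of amino(phenyl)methyl on a carbonyl carbon, so that (amino(phenyl)methyl)carbonyl becomes acetyl.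

Among the measured compounds shown here, only one measured step bears on the series in a single place, a 1.5-fold lower number from compound 1 to compound 3 (0.16 log units; within the scatter). It stayed within the scatter, but it does not touch the group on this carbonyl carbon. For the measured compounds named here, compound 1 and compound 2 differ in more than one place, and their values show only that the two compounds are not separated beyond the scatter. Going by the values given here, no measured compound lacks the amino-bearing group, so the data give no direct guide to this change.

No step beyond the scatter is therefore expected in this assay, and no direction is favoured with confidence. The estimate corresponds to a 1.1-fold higher number from compound 2 to compound 4 (0.03 log units; within the scatter), an expected step within the scatter. For compound 4 the expected value is 15000 nM, with an estimated range of 7000 nM to 35000 nM.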

Compound 4, concentration for 50% growth inhibition: 50000 nM
Beside the measured number, compound 4's estimate is 3.3-fold (0.52 log units) below it; measured number above the stated range.
By their numbers in this assay, from the lowest: compounds 3, 2 and 1 (each within the scatter of the next); then compound 4.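

In this assay, among the compounds shown here, the carbonyl carbon of the ester proves to be a place that responds: methyl in place of amino(phenyl)methyl gives a 3.6-fold higher number from compound 2 to compound 4 (0.55 log units; beyond the scatter), the first step that lies beyond the scatter, and it runs toward weaker inhibition of growth. The flat picture of the earlier compounds therefore holds only while an amino-bearing group stays on this carbonyl carbon, and compound 4, with its acetyl, is the first compound shown without one. Nothing available explains this step, and no measurement beyond the growth read-out bears on it.

On these data alone, the step removes the amino group and the phenyl ring together, so it remains open which of the two carries the difference; an aminomethyl group or a benzyl group on this carbonyl carbon would separate them. Also open, as far as these compounds go, is whether acetyl in place of the amino-bearing acyl group of compound 1 or compound 3 would give a step of similar size, which would show whether the effect holds beyond this single pair.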